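The source may hold more compounds than are shown below. What is called first, only, known or untested is meant among the compounds shown, and "the series" means these compounds.

Measured so far in a physicochemical assay for acid dissociation:

- compound 1, `COc1ccccc1Oc1ccc2c(NCCCNCc3ccco3)ccnc2c1`, 9.28
- compound 2, `COc1ccc(-c2ccc3c(NCCCNCc4ccco4)ccnc3c2)cc1`, 9.47
- compound 3, `c1ccc(CCc2ccc3c(NCCCNCc4ccco4)ccnc3c2)cc1`, 9.47

Compound 3 sits level with compound 2 at the digits given, the two together at the top of the three numbers; no change at the digits printed from compound 2 to compound 3 (within the scatter), and a number 0.19 log units higher from compound 1 to compound 3 (within the scatter). Nothing among these three lies beyond the scatter.

Compound 4, `FC(F)(F)c1cccc(Cc2ccc3c(NCCCNCc4ccco4)ccnc3c2)c1`, differs from compound 3 as follows: 3-(trifluoromethyl)phenyl in place of benzyl on a saturated chain carbon bound to an aromatic carbon. The shared core and the chain common to all four compounds are unchanged.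

Among the compounds with values here, the steps that bear on this are the three exchanges of the group on an aromatic carbon: a number 0.19 log units higher from compound 1 to compound 2 (within the scatter), a number 0.19 log units higher from compound 1 to compound 3 (within the scatter) and no change at the digits printed from compound 2 to compound 3 (within the scatter). All three are within the scatter, so swapping one aromatic side group for another has so far left this assay flat. The change to compound 4 is of the same kind, and no shift beyond the scatter is expected: the step from compound 3 to compound 4 is estimated at a number 0.02 log units lower from compound 3 to compound 4 (within the scatter).

Compound 4 is therefore expected to give about 9.45, within 9.15 to 9.75.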

Compound 4, acid dissociation constant: 9.47
Compound 4: middle estimate off by 0.02 log units, on the low side; measured number inside the range.
By their numbers in this assay, from the lowest: compounds 1, 2, 3 and 4 (each within the scatter of the next).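

In this assay, 3-(trifluoromethyl)phenyl in place of benzyl on a saturated chain carbon bound to an aromatic carbon gives no change at the digits printed from compound 3 to compound 4 (within the scatter). The earlier steps shown here exchanged whole groups on an aromatic carbon; this one shows the same flat reading for a change further out on the side group, with 10 heavy atoms entering where 7 leave, 3 of them fluorine. No supporting data bear on the reason for this flat reading.

As far as these compounds go, all four compounds carry a side group without hydrogen-bond donors or net charge, so it remains open whether an amine or a carboxylic acid on that side group would shift this assay beyond the scatter. Also open, from the compounds shown here alone, is whether a longer chain in place of the chain common to all four compounds would move this number.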